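A few compounds are considered here, and "the series" means these few. Any claim that something is new, unique, unknown or untested is made for them only; others in the source may bear on it.

Measured so far:
- compound 1, `Cc1cc(=O)oc2cc(OCC(=O)NN)ccc12`: in an assay for inhibition of Amine oxidase [flavin-containing] B (Bos taurus), read by fluorescence, with a stated time of 30 min (on this read-out lower numbers stand for stronger inhibition and higher numbers for weaker inhibition), compound 1 gives 874 nM
- compound 2, `Cc1c(C)c2ccc(OCC(=O)NN)cc2oc1=O`: compound 2 gives 484 nM
- compound 3, `Cc1c(C)c2ccc(OCc3nnc(S)s3)cc2oc1=O`: compound 3 gives 572 nM

On these numbers compound 2 cannot be set apart from the other two: the step of a 1.8-fold lower number from compound 1 to compound 2 (0.26 log units; within the scatter) and the step of a 1.2-fold higher number from compound 2 to compound 3 (0.07 log units; within the scatter) are both within the scatter, so the three compounds read as equivalent.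

Compound 4, `Cc1c(C)c2ccc(OCC(=O)N/N=C/c3ccc(Cl)cc3)cc2oc1=O`, is not yet measured. It differs from compound 2 in one place: a group of 9 heavy atoms (7 carbon, 1 nitrogen, 1 chlorine; one six-membered aromatic ring of carbon only) in place of one nitrogen atom, on an amide-type nitrogen. For the measured compounds named here, no measured step touches this exact change. The closest is the step from compound 2 to compound 3, which exchanged the aminocarbamoyl end for a 5-sulfanyl-1,3,4-thiadiazol-2-yl group and left the number within the scatter; the methyl step from compound 1 to compound 2 also stayed within the scatter. The change to compound 4 is larger than either, so the outcome is uncertain. The expected step of a 1.6-fold lower number from compound 2 to compound 4 (0.21 log units; within the scatter) is a modest move toward a lower number. The estimate for compound 4 in this assay is 300 nM, with a range from 80 nM to 1200 nM.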

Compound 4, inhibition constant: 522 nM
For compound 4 the middle estimate is 1.7-fold (0.24 log units) below the measured one; the measured number falls inside the stated range.
By their numbers in this assay, from the lowest: compounds 2, 4, 3 and 1 (each within the scatter of the next).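

In this assay, replacing the amino group on the amide-type nitrogen with a group of 9 heavy atoms that includes a six-membered aromatic ring gives a 1.1-fold higher number from compound 2 to compound 4 (0.03 log units; within the scatter) and so no readable difference. For the compounds shown here, this goes beyond the earlier steps by showing that this end of compound 2 can carry a much bigger group without leaving the scatter. The count of hydrogen-bond donors in the exchanged group also goes from 1 to 0 with no readable difference, and nothing available explains this result.

It remains open whether the chlorine contributes anything, as no compound shown carries the same ring without it or with a methoxy group in its place. Also open, going by these compounds, is how an amine or a carboxylic acid would read on this amide-type nitrogen, and whether the same exchange on the core of compound 1 would give a similar reading.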